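Sulfonylurea series: methyl removal on the aromatic ring

The source may report more compounds than this note shows. Statements on the series, on what has been measured and on what is new or still open speak of the compounds shown alone.

Compound 1 `COc1ccc(OC)c(CNC(=O)NS(=O)(=O)c2ccc(C)cc2)c1` and compound 2 `COc1ccc(OC)c(CNC(=O)NS(=O)(=O)c2ccccc2)c1` share one core. In a functional assay on thoracic aorta (Rattus norvegicus, strain Wistar), with a stated time of 15 min (on this read-out higher numbers stand for an effect only at larger amounts of compound and lower numbers for an effect already at smaller amounts), compound 1 gives > 300000 nM, a limit of the assay and not a number. In this assay compound 2 gives > 300000 nM, likewise a limit. The change between them, (hydrogen in place of methyl on an aromatic carbon), is read as a step that the two limits leave unreadable from compound 1 to compound 2; both values sit at the limit of > 300000 nM in this assay, at which 2 of the 3 values shown sit. Within the data shown here, compound 3 `COc1ccc(Cl)cc1C(C)NC(=O)N(C)S(=O)(=O)c1ccc(C)cc1` gives 13800 nM in this assay, the only number in the set. The difference between the core of compound 3 and the core of compound 1 is not broken down here. Compound 4 `COc1ccc(Cl)cc1C(C)NC(=O)N(C)S(=O)(=O)c1ccccc1` is not yet measured; it differs from compound 3 by hydrogen in place of methyl on an aromatic carbon, the same change as between compound 1 and compound 2. The measured pair gives no readable size for this change, so the expectation for compound 4 rests on compound 3 alone, anchored at 13800 nM. The step is expected to be a 1.1-fold higher number from compound 3 to compound 4 (0.04 log units; within the scatter), within the usual scatter. Compound 4 is expected to give 15000 nM in this assay, between 5000 nM and 60000 nM.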

Compound 4, half-maximal effective concentration: 7200 nM
Beside the measured number, compound 4's estimate is 2.1-fold (0.32 log units) above it, and the stated range covers the measured number.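

In this assay, the change from 4-methylphenyl to phenyl reads as a 1.9-fold lower number from compound 3 to compound 4 (0.28 log units; within the scatter), so on this core the two compounds cannot be told apart. On the other core the same change cannot be read, since both values there are limits of the assay and not numbers: the limit of > 300000 nM in this assay, at which 2 of the 4 values shown sit.

The series therefore holds a single readable instance of this change, and nothing shown tells whether its size carries from one core to another; agreement between the two cores is neither supported nor ruled out.

Open, as far as these compounds go, is whether a different group in place of the methyl on that aromatic ring, such as an amine, a carboxylic acid or a propyl chain, would move the number on the core of compound 3 beyond the usual scatter. Also open, from the compounds shown here alone, is which part of the difference between the core of compound 1 and the core of compound 3 goes with the number of compound 3, 13800 nM.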